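Taking one chloro off a growth inhibitor

A few compounds are considered here, and "the series" means these few. Any claim that something is new, unique, unknown or untested is made for them only; others in the source may bear on it.

Compound 1 (`Cc1ccc(S/C(=C/c2ccc(Br)cc2)C(=O)c2ccc(Cl)cc2)cc1`) measures 25000 nM
Compound 2 (`Cc1ccc(S/C(=C/c2ccc(Cl)cc2)C(=O)c2ccc(Br)cc2)cc1`) measures 10000 nM
Compound 3 (`Cc1ccc(S/C(=C/c2ccc(Cl)cc2Cl)C(=O)c2ccc(Cl)cc2)cc1`) measures 10000 nM

In a functional assay on DU-145 cells (Homo sapiens) for inhibition, read by trypan blue exclusion, with a stated time of 96 h (on this read-out higher numbers stand for weaker inhibition of growth and lower numbers for stronger inhibition of growth), compound 3 reads 10000 nM and stands level with compound 2 at 10000 nM while these two share the lowest number of the three. Compound 1 gives 25000 nM as the highest reading.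

The next molecule is compound 4 (`Cc1ccc(S/C(=C/c2ccc(Cl)cc2)C(=O)c2ccc(Cl)cc2)cc1`), which differs from compound 3 in one place (hydrogen in place of chloro on an aromatic carbon): hydrogen in place of chloro on an aromatic carbon, so that 2,4-dichlorophenyl becomes 4-chlorophenyl.

Among the compounds with values here, only one measured step bears on this place (a 2.5-fold lower number from compound 1 to compound 3 (0.40 log units; beyond the scatter)), and it is modest, with 2,4-dichlorophenyl in place of 4-bromophenyl. Within the data shown here, that step also removes the 4-bromophenyl, so no measured pair shows the chloro alone. Taking the chloro away may hand back part of that step, so in this assay a small move to a higher number is expected, probably no larger than the scatter. The expected step is a 1.5-fold higher number from compound 3 to compound 4 (0.18 log units; within the scatter) and its direction remains uncertain. Compound 4 is estimated at 15000 nM with a likely range from 7000 nM to 30000 nM in this test.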

Compound 4, concentration for 50% growth inhibition: 10000 nM
Beside the measured number, compound 4's estimate is 1.5-fold (0.18 log units) above it; the measured number falls inside the stated range.
By their numbers in this assay, from the lowest: compounds 2, 3 and 4 (each within the scatter of the next); then compound 1.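

In this assay, the chloro on the aromatic carbon ortho to a large group proves dispensable, with no change at the digits printed from compound 3 to compound 4 (within the scatter); the lower number of compound 3 therefore does not depend on it, and the chloro at the 4-position of compound 4 is enough. Compound 4 also isolates the swap of bromo for chloro, and its outcome depends on which aromatic ring carries the halogen: on the ring of compound 1 there is a 2.5-fold lower number from compound 1 to compound 4 (0.40 log units; beyond the scatter), whereas on the other ring, in compound 2, there is no change at the digits printed from compound 2 to compound 4 (within the scatter). No measurement here explains why the two rings differ in this way.

On these data alone, only hydrogen and chloro have been compared directly at the place under study, so it remains open whether a fluoro, a methoxy group or an amine on that carbon would shift the number beyond the scatter. As far as these compounds go, compound 4 reads 10000 nM, and it is also open whether any change to the shared core would give a much lower number.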